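The source may hold more compounds than are shown below. What is called first, only, known or untested is meant among the compounds shown, and "the series" means these compounds.

Working notes on the series.

The shared readout throughout is a functional assay on aorta (Rattus norvegicus); a lower number here means a stronger inhibitor, a higher number a weaker inhibitor. Compound 1 `O=c1ccc(CCOCc2ccccc2)nn1Cc1ccccc1` gives 32300 nM in this assay. Compound 2 `Cn1nc(CCOCc2ccccc2)ccc1=O` is its counterpart with the phenyl removed from the chain carbon on the ring nitrogen; in this assay compound 2 reaches only the limit of > 100000 nM. The change between them, (phenyl in place of hydrogen on a saturated chain carbon bound to an aromatic nitrogen), therefore brings an at least 3.0-fold lower number from compound 2 to compound 1 (0.49 log units; beyond the scatter), a floor on the true size of the step rather than its full value, because of the limit of > 100000 nM in this assay, at which 2 of the 3 values shown sit, sitting on one side of the pair.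

Compound 3 `Cn1nc(CCCO[Si](c2ccccc2)(c2ccccc2)C(C)(C)C)ccc1=O` carries a longer chain ending in a silyl ether instead of the benzyl ether; the difference between its core and that of compound 2 is not broken down here. In this assay compound 3 also sits at the limit of > 100000 nM.

Compound 4 `CC(C)(C)[Si](OCCCc1ccc(=O)n(Cc2ccccc2)n1)(c1ccccc1)c1ccccc1` is to compound 3 what compound 1 is to compound 2: the change is phenyl in place of hydrogen on a saturated chain carbon bound to an aromatic nitrogen, the same change at the same place. On the strength of the pair compound 2 to compound 1, with its step of an at least 3.0-fold lower number from compound 2 to compound 1 (0.49 log units; beyond the scatter), the expectation for compound 4 is a step of an at least 2.2-fold lower number from compound 3 to compound 4 (0.34 log units; beyond the scatter) from compound 3, with the reservation that both the reference step and the starting point rest on a limit. The estimated value for compound 4 in this assay is 45000 nM, with a range from 15000 nM to 150000 nM, and a real chance that only a limit is again reported.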

Compound 4, half-maximal inhibitory concentration: 39900 nM
Estimate against measurement, compound 4: 1.1-fold (0.05 log units) above, and the stated range covers the measured number.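

In this assay, phenyl in place of hydrogen on a saturated chain carbon bound to an aromatic nitrogen (methyl to benzyl) brings an at least 2.5-fold lower number from compound 3 to compound 4 (0.39 log units; beyond the scatter), so the change lowers the number on both the benzyl ether and the silyl ether, and it carries over in direction between the two cores: the same change on two cores in this assay, an at least 3.0-fold lower number (0.49 log units; beyond the scatter) from compound 2 to compound 1 and an at least 2.5-fold lower number (0.39 log units; beyond the scatter) from compound 3 to compound 4; the limit leaves it open whether they differ

Neither step has a full size, only a floor, so the data show that the change carries over but not whether it keeps its size from one core to the other: the limit of > 100000 nM in this assay, at which 2 of the 4 values shown sit.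

Going by these compounds alone, with only two pairs, both starting from a limit, this is no general rule for the series, and the pairs give no reason why the change acts as it does.

Open, on these data alone, is whether a step of measurable size appears from a starting compound that is itself a number rather than a limit, and whether anything other than benzyl at the same place, such as a phenethyl group or a benzyl bearing a carboxylic acid, goes the same way. Also open, as far as these compounds go, is whether the change carries over when the chain end holds an amine rather than either ether.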